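Sulfonamide variation at the aminomethyl side chain

This account rests on a few compounds, and the source may have more. Where it says the series, first, only, none or still open, it means among the compounds named here.

Compound 2 `Cc1cccc(C(=O)Nc2ccc3c(c2)CC(CNS(C)(=O)=O)C3)c1-c1ccc(C(F)(F)F)cc1` carries a methanesulfonamide on the side chain of the shared core. For the measured compounds named here, in an assay on isolated protein for inhibition of microsomal triglyceride transfer protein large subunit (Homo sapiens) (a lower number here means a stronger inhibitor, a higher number a weaker inhibitor), compound 2 gives 150 nM, the higher of the two numbers so far. Going by the values given here, compound 1 `COC(=O)NCC1Cc2ccc(NC(=O)c3cccc(C)c3-c3ccc(C(F)(F)F)cc3)cc2C1` gives 24 nM in this assay; the only measured step, a 6.3-fold higher number from compound 1 to compound 2 (0.80 log units; beyond the scatter), concerns the exchange of the methoxycarbonyl for the methylsulfonyl and not the substituent on the sulfonyl sulfur itself. Compound 3 `Cc1cccc(C(=O)Nc2ccc3c(c2)CC(CNS(=O)(=O)c2cccs2)C3)c1-c1ccc(C(F)(F)F)cc1` differs from compound 2 by thiophen-2-yl in place of methyl on a sulfonyl sulfur. Among the compounds with values here, no measured step bears on this change; no sulfonyl group other than methylsulfonyl has been tested. The step expected in this assay is therefore no more than modest, with no direction supported by the data, and the range is set wide. For compound 3 the estimate in this assay is 100 nM, between 30 nM and 400 nM. This corresponds to an expected 1.5-fold lower number from compound 2 to compound 3 (0.18 log units; within the scatter).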

Compound 3, half-maximal inhibitory concentration: 14 nM
Compound 3: the middle estimate sits 7.1-fold (0.85 log units) above what was measured, outside the stated range (below it).
By their numbers in this assay, from the lowest: compounds 3 and 1 (each within the scatter of the next); then compound 2.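

In this assay the group on the sulfonyl sulfur clearly counts: thiophen-2-yl in place of methyl gives an 11-fold lower number from compound 2 to compound 3 (1.03 log units; beyond the scatter) and is a large step, so the sulfonamide link alone does not set the number. Set against methoxycarbonyl on the amine nitrogen, (thiophen-2-yl)sulfonyl gives a 1.7-fold lower number from compound 1 to compound 3 (0.23 log units; within the scatter) and no separation from it, so the weaker number belongs to methylsulfonyl, not to both sulfonyl groups shown. No measurement at hand accounts for the size of this step.

Still open, from the compounds shown here alone, is whether the thiophene ring itself matters or whether other groups on the sulfur would serve as well. Phenyl, thiophen-3-yl or a longer chain such as n-butyl on the sulfonyl sulfur would help separate these readings.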